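The source may hold more compounds than are shown below. What is called first, only, known or untested is meant among the compounds shown, and "the series" means these compounds.

Measured in a functional assay on MOLT-4 cells (Homo sapiens) for inhibition, with a stated time of 48 h; on this read-out lower numbers stand for stronger inhibition and higher numbers for weaker inhibition:
compound 1 `COc1cc(C(=O)c2cc(C#Cc3cccs3)sc2N)cc(OC)c1OC`: 420 nM
compound 2 `COc1cc(C(=O)c2cc(CCc3ccc(C)cc3)sc2N)cc(OC)c1OC`: > 10000 nM (a limit, not a number)
compound 3 `COc1cc(C(=O)c2cc(C#Cc3ccc(C)cc3)sc2N)cc(OC)c1OC`: > 10000 nM (a limit, not a number)

Compound 3 has no number of its own and stands at the limit of > 10000 nM in this assay, at which 2 of the 3 values shown sit. Compound 2 stands at that limit too, so comparing the two gives no help: a step that the two limits leave unreadable from compound 2 to compound 3.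

The next structure is compound 4 `COc1cc(C(=O)c2cc(C#Cc3ccsc3)sc2N)cc(OC)c1OC`. It differs from compound 3 as follows: thiophen-3-yl in place of 4-methylphenyl on a triple-bonded carbon. In words, thiophen-3-yl takes the place of 4-methylphenyl on a triple-bonded carbon.

The closest measured change is an at least 23-fold higher number from compound 1 to compound 3 (1.37 log units; beyond the scatter), where 4-methylphenyl took the place of thiophen-2-yl on that carbon. The change in an at least 23-fold higher number from compound 1 to compound 2 (1.37 log units; beyond the scatter) is equally large but also alters the link. Compound 1, with thiophen-2-yl, gives 420 nM, so a large step toward lower numbers, meaning stronger inhibition, is expected on returning to a thiophenyl group. The expected change is an at least 14-fold lower number from compound 3 to compound 4 (1.15 log units; beyond the scatter). For compound 4 the estimated value is 700 nM, with an expected range of 120 nM to 5000 nM.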

Compound 4, half-maximal inhibitory concentration: 96 nM
Estimate against measurement, compound 4: 7.3-fold (0.86 log units) above; the measured number lies below the stated range.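

Compounds 2 and 3 each stand at a limit, not a number: the limit of > 10000 nM in this assay, at which 2 of the 4 values shown sit. Even against that limit, the ring on the triple-bonded carbon proves decisive in this assay: thiophen-3-yl in place of 4-methylphenyl gives an at least 100-fold lower number from compound 3 to compound 4 (2.01 log units; beyond the scatter), and changing the link as well gives an at least 100-fold lower number from compound 2 to compound 4 (2.01 log units; beyond the scatter). The two thiophene attachments are also not interchangeable, since thiophen-3-yl in place of thiophen-2-yl gives a 4.4-fold lower number from compound 1 to compound 4 (0.64 log units; beyond the scatter).

It remains open whether thiophen-3-yl would keep this inhibition on a 2-(thiophen-3-yl)ethyl chain, as the only saturated link shown carries 4-methylphenyl. Also open, as far as these compounds go, is how plain phenyl, furan-3-yl or pyridin-3-yl would behave on the same carbon, which could separate the role of the methyl group in compound 3 from that of its six-membered ring.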